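The source may hold more compounds than are shown below. What is called first, only, known or untested is meant among the compounds shown, and "the series" means these compounds.

Measured so far in a functional assay on U-373MG ATCC cells (Homo sapiens) for inhibition, read by MTT assay, with a stated time of 72 h; a lower number here means a stronger inhibitor, a higher number a weaker inhibitor:
compound 1 `CC1(C)CC(NC(=S)NCc2ccccc2)c2cc(F)ccc2O1`, 27000 nM;
compound 2 `CC1(C)CC(NC(=S)Nc2ccc([N+](=O)[O-])cc2)c2cc(Cl)ccc2O1`, 3000 nM;
compound 3 `CC1(C)CC(NC(=S)NCc2ccccc2)c2cc(Cl)ccc2O1`, 64000 nM.

Compound 2 gives the lowest number of the three. How compound 2 differs from compound 3 is not broken down here. Between compound 3 and compound 1 the only change is fluoro in place of chloro on an aromatic carbon, and it brought a 2.4-fold lower number from compound 3 to compound 1 (0.37 log units; beyond the scatter). Compound 4 `CC1(C)CC(NC(=S)Nc2ccc([N+](=O)[O-])cc2)c2cc(F)ccc2O1` is not yet measured; it arises from compound 2 by fluoro in place of chloro on an aromatic carbon, the same change at the same place as seen from compound 3 to compound 1. Within the data shown here, compound 4 is expected to show a 2.0-fold lower number from compound 2 to compound 4 (0.30 log units; within the scatter) in this assay, a step of similar size, resting on a 2.4-fold lower number from compound 3 to compound 1 (0.37 log units; beyond the scatter) as the one measured instance of this change. The estimate for compound 4 is 1500 nM, with a range from 500 nM to 5000 nM.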

Compound 4, half-maximal inhibitory concentration: 3000 nM
Compound 4: the middle estimate sits 2.0-fold (0.30 log units) below what was measured, and the stated range covers the measured number.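

In this assay, fluoro in place of chloro on an aromatic carbon gave no change at the digits printed from compound 2 to compound 4 (within the scatter). Set beside the earlier instance, the two steps cannot be told apart: the same change on two cores in this assay, a 2.4-fold lower number (0.37 log units; beyond the scatter) from compound 3 to compound 1 and no change at the digits printed (within the scatter) from compound 2 to compound 4, 2.4-fold (0.37 log units) apart, within the scatter of two such steps. This shows that the change behaves compatibly on these two cores, but two instances, one of them within the scatter, do not establish a dependable gain, a fixed size or any transfer to a third core.

The compounds shown leave open how a bromo, methoxy or trifluoromethyl group at this aromatic carbon would compare with chloro and fluoro. Also open, as far as these compounds go, is how the step would read with a nitrile or an amine in place of the nitro group.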